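A few compounds are considered here, and "the series" means these few. Any claim that something is new, unique, unknown or untested is made for them only; others in the source may bear on it.

Measured so far in a functional assay on L1210 cells (Mus musculus) for cytotoxicity; a lower number here means a stronger inhibitor, a higher number a weaker inhibitor:
Compound 1 `Cc1cn([C@@H]2O[C@@H]3COP(=O)(O)O[C@H]3[C@H]2O)c(=O)nc1N`: > 200 ug/mL
Compound 2 `CCCCCc1cn([C@@H]2O[C@@H]3CO[PH](O)(O)O[C@H]3[C@H]2O)c(=O)nc1N`: > 200 ug/mL

The value for compound 1 in this assay, > 200 ug/mL, is a limit of the assay, not a number. The value for compound 2, > 200 ug/mL, is likewise a limit. For the measured compounds named here, both results therefore sit at the same point, (the limit of > 200 ug/mL in this assay, at which 2 of the 2 values shown sit), so no step between measured compounds can be read off.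

Compound 3 `CCCCc1cn([C@@H]2O[C@@H]3COP(=O)(O)O[C@H]3[C@H]2O)c(=O)nc1N` differs from compound 1 by propyl in place of hydrogen on a saturated chain carbon bound to an aromatic carbon. With both measured values resting at the limit, no step beyond the usual scatter is expected; the step that the limit leaves unreadable from compound 1 to compound 3 is the estimate. Compound 3 is expected at about 300 ug/mL, within a range from 100 ug/mL to 2000 ug/mL, most likely again reported only as a limit.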

Compound 3, concentration for 50% inhibition: > 200 ug/mL
Compound 3: no number, only a limit; the forecaster's own chance of this, stated with the estimate: 85%; the middle value lies beyond the limit too.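

Compound 1 and compound 3 both give a limit rather than a number, so no step between them can be read: the limit of > 200 ug/mL in this assay, at which 3 of the 3 values shown sit.

The compounds shown leave open how strongly, if at all, any of them inhibits these cells, and whether the longer chain makes any difference.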